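The source may hold more compounds than are shown below. What is called first, only, known or untested is meant among the compounds shown, and "the series" means these compounds.

Working notes on the series. Two compounds have a number in a functional assay on HOS cells (Homo sapiens) for inhibition, read by CCK-8 assay, with a stated time of 72 h, tested at 1 uM (a lower number here means less inhibition, a higher number more inhibition at the concentration tested (going by the name of the read-out)), so far. Compound 1 `CCN1C(=O)CSC1c1cccc(C(=O)NCCCCc2ccccc2)c1` gives 6% in this assay. Among the compounds with values here, compound 2 `CCOc1ccccc1N1C(=O)C(C)SC1c1cccc(C(=O)NCCCCc2ccccc2)c1` gives 82% in this assay, the higher of the two numbers; its only neighbour on the numbers is compound 1, whose value lies below it by a gap beyond the scatter. Compound 3 `COc1ccccc1N1C(=O)C(C)SC1c1cccc(C(=O)NCCCCc2ccccc2)c1` has not yet been measured in this assay. It differs from compound 2 in one place: hydrogen in place of methyl on a saturated chain carbon bound to an oxygen on an aromatic ring. Within the data shown here, no step between two measured compounds shows what this change does, and compound 1 against compound 2 differs in several places at once, so it gives no guide. The change is small in what is counted. A step within the scatter is expected, if anything slightly downward. The estimated step is a number 10 percentage points lower from compound 2 to compound 3 (within the scatter). For compound 3 the estimated value in this assay is 72%, with a range from 45% to 90%.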

Compound 3, a percentage reported as inhibition, at one concentration (the size of the read-out at that concentration, not a potency): 82%
Beside the measured number, compound 3's estimate is 10 percentage points below it, and the stated range covers the measured number.
By their numbers in this assay, from the lowest: compound 1; then compounds 2 and 3 (each within the scatter of the next).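

Going from ethoxy to methoxy reads in this assay as no change at the digits printed from compound 2 to compound 3 (within the scatter), the first step measured at this position, which compound 1 against compound 2 could not provide. Hydrogen in place of methyl on a saturated chain carbon bound to an oxygen on an aromatic ring therefore leaves the inhibition at the tested concentration within the scatter, so the 2-ethoxyphenyl and 2-methoxyphenyl compounds cannot be told apart here. Nothing available bears on the reason for this result.

Going by these compounds, whether the position accepts larger or different groups stays open, for instance a longer chain such as propoxy, a hydroxy group or an amine at the end of the chain. A single concentration also leaves open whether compound 2 and compound 3 would separate in a full concentration series.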